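The compounds below may be only part of what the source reports. "The series", "measured", "known", "first", "only" and "open" are said of these compounds alone.

In a functional assay on L02 cells (Homo sapiens) for inhibition, read by Griess assay, with stated times of 1 h and 24 h (on this read-out higher numbers stand for weaker inhibition and lower numbers for stronger inhibition), compound 1 `CN(C)c1nc(/C=C/c2ccccc2)nc2ccsc12` gives > 1000000 nM, which is a limit. Among the measured compounds shown here, compound 2 `CN1CCN(c2nc(/C=C/c3ccccc3)nc3ccsc23)CC1` gives 198000 nM, the only actual number so far. Compound 3 `C(=C/c1nc(Nc2ccccc2)c2sccc2n1)\c1ccccc1` differs from compound 2 as follows: anilino in place of 4-methylpiperazin-1-yl on an aromatic carbon. For the measured compounds named here, the sole measured step, an at least 5.0-fold lower number from compound 1 to compound 2 (0.70 log units; beyond the scatter), starts from a limit (the limit of > 1000000 nM in this assay, at which 1 of the 2 values shown sits) and involves a different pair of groups, so it sets no direction here. No step beyond the scatter is therefore expected in this assay. The expected change is a 1.3-fold lower number from compound 2 to compound 3 (0.12 log units; within the scatter). For compound 3 the estimated value is 150000 nM, with an expected range of 30000 nM to 700000 nM.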

Compound 3, half-maximal inhibitory concentration: > 1000000 nM
Compound 3: a limit, no number; the forecaster's own chance of this, stated with the estimate: 30%; middle value at least 6.6-fold (0.82 log units) away from the limit.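

Anilino in place of 4-methylpiperazin-1-yl on this aromatic carbon gives an at least 5.0-fold higher number from compound 2 to compound 3 (0.70 log units; beyond the scatter) in this assay, so a six-membered aromatic ring of carbon only does not carry over the readable inhibition of compound 2. Among the three groups shown at this place, only 4-methylpiperazin-1-yl gives a number, and the step between compound 1 and compound 3 cannot be read. The comparison rests largely on a limit: the limit of > 1000000 nM in this assay, at which 2 of the 3 values shown sit.

Going by these compounds, whether the number depends on the piperazine ring or on its second nitrogen stays open. A morpholine or an unsubstituted piperazine at this place would bear on that.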